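The compounds below may be only part of what the source reports. "The series", "measured", "known", "first", "only" and "open" are said of these compounds alone.

Measured so far in an assay on CHO cells for antagonist activity at transient receptor potential cation channel subfamily V member 1 (Homo sapiens), read by FLIPR; on this read-out lower numbers stand for stronger inhibition and higher numbers for weaker inhibition:
compound 1 `CCCN(CCC)c1cc(C(F)(F)F)ccc1CNC(=O)C(C)c1ccc(NS(C)(=O)=O)c(F)c1`: 0.3 nM
compound 2 `CCCOc1cc(C(F)(F)F)ccc1CNC(=O)C(C)c1ccc(NS(C)(=O)=O)c(F)c1`: 2 nM
compound 3 `CCCCCc1cc(C(F)(F)F)ccc1CNC(=O)C(C)c1ccc(NS(C)(=O)=O)c(F)c1`: 0.4 nM

Compound 3 holds the second highest of the three numbers in this assay. Its nearest neighbour is compound 1, a difference within the scatter (a 1.3-fold higher number from compound 1 to compound 3 (0.12 log units; within the scatter)); its furthest is compound 2 (a 5.0-fold lower number from compound 2 to compound 3 (0.70 log units; beyond the scatter)). Compound 4 `CC(C(=O)NCc1ccc(C(F)(F)F)cc1-c1ccc(C(C)(C)C)cc1)c1ccc(NS(C)(=O)=O)c(F)c1` differs from compound 3 by 4-(tert-butyl)phenyl in place of pentyl on an aromatic carbon. Both measured steps touch this same site: the step of a 5.0-fold lower number from compound 2 to compound 3 (0.70 log units; beyond the scatter) was beyond the scatter, the step of a 1.3-fold higher number from compound 1 to compound 3 (0.12 log units; within the scatter) was not. For the measured compounds named here, no measured compound carries a ring at this site, so the expectation is loose. Compound 4 is expected to stay close to compound 3, with a slight drift to a higher number: a 2.5-fold higher number from compound 3 to compound 4 (0.40 log units; beyond the scatter). The estimate for compound 4 is 1 nM, between 0.2 nM and 5 nM.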

Compound 4, inhibition constant: 1.1 nM
For compound 4 the middle estimate is 1.1-fold (0.04 log units) below the measured one; the measured number falls inside the stated range.
By their numbers in this assay, from the lowest: compounds 1 and 3 (each within the scatter of the next); then compounds 4 and 2 (each within the scatter of the next).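

In this assay, this site on an aromatic carbon also tolerates a ring: 4-(tert-butyl)phenyl, the only ring here among the compounds shown, gives only modest rises, with a 2.8-fold higher number from compound 3 to compound 4 (0.44 log units; beyond the scatter) and a 3.7-fold higher number from compound 1 to compound 4 (0.56 log units; beyond the scatter), while a 1.8-fold lower number from compound 2 to compound 4 (0.26 log units; within the scatter) stays within the scatter. The change from pentyl to this larger group therefore costs little, and compound 4 cannot be told apart from the propoxy compound 2. No measurement shown gives a reason for these steps.

Going by these compounds, it stays open whether the tert-butyl group contributes anything compared with a plain phenyl. Also open, on these data alone, is how a pyridine ring, a carboxylic acid or a chain longer than pentyl would fare at this site.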